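This account rests on a few compounds, and the source may have more. Where it says the series, first, only, none or still open, it means among the compounds named here.

Working notes on the series. In a functional assay on NCI-H460 cells (Homo sapiens) for antiproliferative activity, read by MTT assay, with a stated time of 48 h (on this read-out higher numbers stand for weaker inhibition and lower numbers for stronger inhibition), compound 1 (`COc1ccc(-c2nc3cccc(-c4cc(OC)c(OC)c(OC)c4)c3o2)cc1F`) gives 2800 nM and compound 2 (`COc1cc(-c2cccc3nc(-c4ccc(F)cc4)oc23)cc(OC)c1OC`) gives 8700 nM as the higher of the two numbers, so compound 2 stands as the weaker inhibitor of this pair. Compound 3 (`COc1cc(-c2cccc3nc(-c4ccc(Br)cc4)oc23)cc(OC)c1OC`) differs from compound 2 by bromo in place of fluoro on an aromatic carbon, para to a large group, which also reads as 4-fluorophenyl to 4-bromophenyl. Within the data shown here, the only measured step at this group is a 3.1-fold higher number from compound 1 to compound 2 (0.49 log units; beyond the scatter) and it is modest. That step replaces 3-fluoro-4-methoxyphenyl by 4-fluorophenyl, not one halogen by another, so it bears only loosely on the new change and gives no firm direction. No swap of one halogen for another has been measured. In this assay the expectation is therefore a step no larger than that one, more likely none beyond the scatter, with a slight lean toward a lower number. The expected step is a 1.3-fold lower number from compound 2 to compound 3 (0.13 log units; within the scatter) on present data. The estimate for compound 3 is 6500 nM with an expected range of 2500 nM to 16000 nM in this read-out.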

Compound 3, half-maximal inhibitory concentration: > 25000 nM
Compound 3 was reported as a limit; the forecaster's own chance of this, stated with the estimate: 5%; middle value at least 3.8-fold (0.58 log units) from the limit.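

In this assay, among these compounds, this is the first exchange of one halogen for another at this position, and the series proves sensitive to it: bromo in place of fluoro gives an at least 2.8-fold higher number from compound 2 to compound 3 (0.45 log units; beyond the scatter), a step beyond the scatter rather than the near-neutral change that the earlier pair left possible. Set against the 3-fluoro-4-methoxyphenyl group, 4-bromophenyl gives an at least 8.9-fold higher number from compound 1 to compound 3 (0.95 log units; beyond the scatter), so the three groups now fall in one order in this read-out, with compound 1 giving the lowest number, compound 2 the next and compound 3 the highest. In this assay compound 3 gives > 25000 nM, which is a limit and not a number, so both new steps give only a least size: the limit of > 25000 nM in this assay, at which 1 of the 3 values shown sits.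

The compounds shown leave open how far the number for compound 3 lies past that limit, and so whether its step from compound 2 is modest or much larger. They also leave open whether the loss belongs to bromo alone or extends to other groups at this place, such as chloro, an amine or a carboxylic acid.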